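The source may report more compounds than this note shows. Statements on the series, on what has been measured and on what is new or still open speak of the compounds shown alone.

Compound 3 `O=C(CCCc1cccc(Cl)c1)Nc1nc2ccccc2c(=O)s1` gives in an assay on CHO cells for displacement of a labelled ligand from adenosine receptor A2b (Homo sapiens), read by scintillation counting, with a stated time of 75 min (a higher number here means a weaker inhibitor, a lower number a stronger inhibitor), only a limit, >= 1000 nM, rather than a number. Its two measured relatives are compound 1 `COc1cccc(CCC(=O)Nc2nc3ccccc3c(=O)s2)c1`, which in this assay gives 225 nM, and compound 2 `O=C(CCc1ccccc1F)Nc1nc2ccccc2c(=O)s1`, which in this assay gives 801 nM. Compound 4 `O=C(CCc1ccc(Cl)c(Cl)c1)Nc1nc2ccccc2c(=O)s1` differs from compound 3 by 3,4-dichlorophenyl in place of 3-chlorobenzyl on a saturated chain carbon, two bonds along the chain from a carbonyl carbon. Going by the values given here, the steps that bear on this change are an at least 4.4-fold higher number from compound 1 to compound 3 (0.64 log units; beyond the scatter) and an at least 1.2-fold higher number from compound 2 to compound 3 (0.09 log units; that floor lies within the scatter), since both likewise exchange the 3-chlorobenzyl group of compound 3 for another ring. The first of them points toward a lower number for compound 4; the second allows no shift beyond the scatter. Compound 4 is therefore expected to give about 600 nM, within 150 nM to 2500 nM, an expected step of an at least 1.6-fold lower number from compound 3 to compound 4 (0.22 log units; that floor lies within the scatter).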

Compound 4, inhibition constant: > 1000 nM
Compound 4 gave a limit, no number; the forecaster's own chance of this, stated with the estimate: 30%; at least 1.6-fold (0.22 log units) between middle value and limit.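

Swapping 3-methoxyphenyl for 3,4-dichlorophenyl at this place gives an at least 4.4-fold higher number from compound 1 to compound 4 (0.64 log units; beyond the scatter), so a second chlorine-bearing ring also stands apart from compound 1. Against 2-fluorophenyl, the change gives an at least 1.2-fold higher number from compound 2 to compound 4 (0.09 log units; that floor lies within the scatter), which does not separate the two groups. In this assay compound 4 gives a limit and not a number, and its step from compound 3 cannot be read because compound 3 also stands at a limit: the limit of >= 1000 nM in this assay, at which 1 of the 4 values shown sits.

On these data alone, how far compound 3 and compound 4 truly lie from that limit stays open. So does whether a 3-methoxybenzyl group or a phenyl ring carrying an amine would give a readable number.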